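A few compounds are considered here, and "the series" means these few. Any claim that something is new, unique, unknown or untested is made for them only; others in the source may bear on it.

Measured compounds:
compound 1, `CNc1nncc2c(C)ncn12`: a limit of > 48000 nM in a functional assay for inhibition, with Homo sapiens as the target; a lower number here means a stronger inhibitor, a higher number a weaker inhibitor
compound 2, `CSc1nncc2c(C)ncn12`: a limit of > 48000 nM in this assay
compound 3, `Cc1ncn2c(N(C)C)nncc12`: a limit of > 48000 nM in this assay

Compound 3 therefore stands at the limit of > 48000 nM in this assay, at which 3 of the 3 values shown sit, where the other two values also sit. None of the three steps among them can be read: the step that the two limits leave unreadable from compound 1 to compound 2, the step that the two limits leave unreadable from compound 1 to compound 3 and the step that the two limits leave unreadable from compound 2 to compound 3 all lie between two limits.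

Compound 4, `Cc1ncn2c(NN)nncc12`, differs from compound 3 by aminoamino in place of dimethylamino on an aromatic carbon. The steps that touch the same place, those from compound 1 to compound 3 and from compound 2 to compound 3, bear on this change, but both are unreadable, so no size or direction for the step in this assay can be drawn from them. Since every measured value is a limit, the expectation for compound 4 is that it too stays at the limit, which amounts to an expected step of a number no higher from compound 3 to compound 4 (the limit leaves the size open). Compound 4 is thus estimated at 48000 nM in this assay, within a range from 15000 nM to 150000 nM.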

Compound 4, half-maximal inhibitory concentration: > 48000 nM
Compound 4 ended at the assay's limit; the forecaster's own chance of this, stated with the estimate: 80%; the middle value lies on the limit itself.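

Compound 4 sits at the same limit as compound 1, compound 2 and compound 3, so none of the steps among these four compounds can be read in this assay: the limit of > 48000 nM in this assay, at which 4 of the 4 values shown sit.

The compounds shown leave open how strongly any of them inhibits, and whether changing the group on the aromatic carbon alters that inhibition at all.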